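From an allyl ether to a free hydroxyl group

The source may report more compounds than this note shows. Statements on the series, on what has been measured and on what is new or still open speak of the compounds shown alone.

Compound 2 `C=CCOC[C@H]1CN(C)CC[C@@H]1c1ccc(Cl)cc1` gives 60 nM in an assay on striatum with sodium-dependent dopamine transporter (Rattus norvegicus) as the target; on this read-out lower numbers stand for stronger inhibition and higher numbers for weaker inhibition. Compound 1 `CN1CC[C@H](c2ccc(Cl)cc2)[C@@H](C(=O)OCCCCCc2ccccc2)C1` gives 53 nM in this assay, and the two numbers lie within the scatter of each other. Compound 3 `CN1CC[C@H](c2ccc(Cl)cc2)[C@@H](CCCO)C1` differs from compound 2 by 2-hydroxyethyl in place of allyloxy on a saturated chain carbon bound to a saturated ring carbon. Among the measured compounds shown here, no measured pair shows this change, so the expected step of a 2.5-fold higher number from compound 2 to compound 3 (0.40 log units; beyond the scatter) is a modest rise, a little beyond the scatter, with wide uncertainty in both directions. Compound 3 is estimated at 150 nM, within 50 nM to 450 nM.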

Compound 3, inhibition constant: 16 nM
Compound 3: the middle estimate sits 9.4-fold (0.97 log units) above what was measured; the measured number lies below the stated range.
By their numbers in this assay, from the lowest: compound 3; then compounds 1 and 2 (each within the scatter of the next).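

In this assay, the change from allyloxy to 2-hydroxyethyl gives a 3.8-fold lower number from compound 2 to compound 3 (0.57 log units; beyond the scatter), a modest step beyond the scatter. This shows that the number responds to the side chain at this place, which compounds 1 and 2 alone, differing in more than one place, could not show. Nothing available here accounts for the step.

This single step does not separate the gain of a hydrogen-bond donor from the loss of the double bond. As far as these compounds go, whether an amine, a carboxylic acid or a longer chain ending in hydroxyl would lower the number further remains open.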